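Chloro for hydrogen on a quinazolinone-linked anilino series

A few compounds are considered here, and "the series" means these few. Any claim that something is new, unique, unknown or untested is made for them only; others in the source may bear on it.

Of the compounds shown here, three have been tested in a functional assay on the whole organism (strain albino) for inhibition, with Rattus norvegicus as the target, read by paw edema, with a stated time of 1 h, at a dose of 100 mg/kg by the oral route; a higher number here means more inhibition at the dose given (going by the name of the read-out), a lower number less inhibition. Compound 1 `O=C(CSc1nc(-c2ccccc2)c(C(=O)O)c(=O)[nH]1)Nn1c(COc2ccc(Cl)cc2Cl)nc2ccccc2c1=O` gives 69.1% in this assay. Compound 2 `O=C(CSc1nc(-c2ccc(Cl)cc2)c(C(=O)O)c(=O)[nH]1)Nn1c(COc2ccc(Cl)cc2Cl)nc2ccccc2c1=O` differs from it by chloro in place of hydrogen on an aromatic carbon and gives 58.2%, so this change made a number 10.9 percentage points lower from compound 1 to compound 2 (beyond the scatter). Compound 3 `N#Cc1c(Nc2ccccc2)nc(SCC(=O)Nn2c(COc3ccc(Cl)cc3Cl)nc3ccccc3c2=O)nc1-c1ccccc1` rests on a different core; how the two cores differ is not broken down here. In this assay compound 3 gives 77.3%, a number close to that of compound 1 and well apart from that of compound 2.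

Compound 4 `N#Cc1c(Nc2ccc(Cl)cc2)nc(SCC(=O)Nn2c(COc3ccc(Cl)cc3Cl)nc3ccccc3c2=O)nc1-c1ccccc1` is not yet measured. It differs from compound 3 by chloro in place of hydrogen on an aromatic carbon, the same change seen between compound 1 and compound 2, at the same kind of place on the ring, here read one bond further out as anilino to (4-chlorophenyl)amino. Because a number 10.9 percentage points lower from compound 1 to compound 2 (beyond the scatter) was a modest fall, a comparable step is expected for compound 4, namely a number 10.3 percentage points lower from compound 3 to compound 4 (beyond the scatter). Compound 4 is thus estimated to give 67% in this assay, with a plausible range from 55% to 79%.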

Compound 4, a percentage reported as inhibition, in the whole organism at one dose (the size of the read-out at that dose, not a potency): 54.6%
Beside the measured number, compound 4's estimate is 12.4 percentage points above it; the whole stated range lies above it.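

In this assay, chloro in place of hydrogen on the second core gives a number 22.7 percentage points lower from compound 3 to compound 4 (beyond the scatter), so the change lowers the read-out here as it did on the first core. The two steps point the same way, and their sizes cannot be told apart: the same change on two cores in this assay, a number 10.9 percentage points lower (beyond the scatter) from compound 1 to compound 2 and a number 22.7 percentage points lower (beyond the scatter) from compound 3 to compound 4, 11.8 percentage points apart, within the scatter of two such steps. This shows that the direction of the change carried over between these two cores, but two pairs cannot establish a general rule, and the numbers do not explain why inhibition falls; each is also the size of the effect at a single dose, not a potency.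

The compounds shown leave open whether the fall is specific to chloro, since no fluoro, methyl or methoxy group stands in that place on either core. They also leave open how a group such as an amine or a carboxylic acid on the anilino ring of compound 3 would behave in this assay.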